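Swapping Chloro for Amino at One Aromatic Carbon

The source may hold more compounds than are shown below. What is called first, only, known or untested is meant among the compounds shown, and "the series" means these compounds.

Compound 1, `Nc1nn(C(=O)Nc2ccc(Cc3ccccc3)cc2)c2ccccc12`: 48600 nM
Compound 2, `Nc1nn(C(=O)Nc2ccc(Cc3ccccc3)cc2)c2ccc(Cl)cc12`: > 100000 nM

Both compounds share one core and differ at a single aromatic carbon. In a functional assay on A549 cells (Homo sapiens) for antiproliferative activity, read by sulforhodamine B assay, with a stated time of 48 h (on this read-out higher numbers stand for weaker inhibition of growth and lower numbers for stronger inhibition of growth), compound 1 gives 48600 nM. For compound 2 the read-out is a limit of the assay, > 100000 nM. Within the data shown here, compound 2 therefore sits at the limit of > 100000 nM in this assay, at which 1 of the 2 values shown sits, so only one side of its value is known. The step of an at least 2.0-fold higher number from compound 1 to compound 2 (0.31 log units; beyond the scatter) shows that chloro in place of hydrogen weakened growth inhibition.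

Compound 3, `Nc1ccc2c(c1)c(N)nn2C(=O)Nc1ccc(Cc2ccccc2)cc1`, carries the change (amino in place of chloro on an aromatic carbon). Among the measured compounds shown here, no measured step involves an amino group, so the only guidance is the chloro step itself. As far as these compounds go, removing chloro undoes the change that produced an at least 2.0-fold higher number from compound 1 to compound 2 (0.31 log units; beyond the scatter), which points back toward the region where compound 1 stands, while the effect of adding amino at this place is unknown. The expected step is an at least 1.6-fold lower number from compound 2 to compound 3 (0.22 log units; that floor lies within the scatter), with no firm direction beyond the scatter. Compound 3 is estimated at 60000 nM, with a range from 20000 nM to 200000 nM, and a real chance that this assay again reports only a limit.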

Compound 3, concentration for total growth inhibition: 57100 nM
Estimate against measurement, compound 3: 1.1-fold (0.02 log units) above; measured number inside the range.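

In this assay, putting amino where compound 1 has hydrogen gives a 1.2-fold higher number from compound 1 to compound 3 (0.07 log units; within the scatter), so compound 1 and compound 3 cannot be told apart on this read-out, and this aromatic carbon evidently accepts at least one group other than hydrogen without a step beyond the scatter. Among these compounds, this is what the earlier pair could not show: chloro was the only group seen at this carbon, so the weakened growth inhibition might have followed any group placed there, whereas amino does not repeat that step. Set against the chloro compound, the exchange gives an at least 1.7-fold lower number from compound 2 to compound 3 (0.24 log units; that floor lies within the scatter), but this step has only a floor, and the value of compound 2 is a limit of the assay and not a number: the limit of > 100000 nM in this assay, at which 1 of the 3 values shown sits.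

The compounds shown carry only hydrogen, chloro or amino at this carbon, so it remains open whether the step seen with chloro belongs to chloro alone or would also appear with a group such as bromo, methyl or methoxy. Also open, as far as these compounds go, is whether a larger group here, such as a carboxylic acid or a longer chain, would leave the read-out within the scatter of compound 1 or move it in either direction.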